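From 3-methylphenyl to 2-fluorophenyl at the assay limit

A few compounds are considered here, and "the series" means these few. Any claim that something is new, unique, unknown or untested is made for them only; others in the source may bear on it.

Compound 1 (`Cc1cccc(NNC(=O)c2ccc(NS(=O)(=O)c3cnc(O)nc3O)cc2)c1`) and compound 2 (`Cc1cccc(NNC(=O)c2cccc(NS(=O)(=O)c3cnc(O)nc3O)c2)c1`) were both tested in a functional assay on OVCAR-3 cells (Homo sapiens) for antiproliferative activity, read by MTT assay, with a stated time of 24 h; on this read-out lower numbers stand for stronger inhibition and higher numbers for weaker inhibition. Compound 1 gives only a limit, > 20000 nM. Compound 2 also gives only a limit, > 20000 nM, so no exact figure fixes its place. The data so far come down to the limit of > 20000 nM in this assay, at which 2 of the 2 values shown sit.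

Compound 3 (`O=C(NNc1ccccc1F)c1cccc(NS(=O)(=O)c2cnc(O)nc2O)c1`) keeps the core of compound 2, with 2-fluorophenyl in place of 3-methylphenyl on an amine nitrogen. Among the compounds with values here, no measured pair shows what this exchange does, so in this assay no step beyond the usual scatter is expected, and compound 3 may well remain at the limit. The expected change is a number no higher from compound 2 to compound 3 (the limit leaves the size open). For compound 3, the estimated half-maximal inhibitory concentration is 20000 nM, with an expected range of 7000 nM to 40000 nM.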

Compound 3, half-maximal inhibitory concentration: 17000 nM
For compound 3 the middle estimate is 1.2-fold (0.07 log units) above the measured one, and the stated range covers the measured number.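

In this assay compound 3 is the first compound shown to give an exact number, 17000 nM, so 2-fluorophenyl on an amine nitrogen yields a value that can be placed. With 3-methylphenyl on the same core, compound 2 yielded only a limit. As far as these compounds go, the exchange gives an at least 1.1-fold lower number from compound 2 to compound 3 (0.07 log units; that floor lies within the scatter), so only a floor is known for this step and its true size stays open. The other values shown offer no exact number to compare with compound 3: the limit of > 20000 nM in this assay, at which 2 of the 3 values shown sit.

The compounds shown leave open whether 2-fluorophenyl would give a measurable number on the core of compound 1 as well. They also leave open how this place responds to other groups, such as a 4-methoxyphenyl, a pyridine ring or a longer alkyl chain.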